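The source may hold more compounds than are shown below. What is called first, only, known or untested is meant among the compounds shown, and "the series" means these compounds.

Working notes on the series. Compound 1 `CC[C@@H]1/C=C(\C)C[C@H](C)C[C@H](OC)[C@H]2O[C@@](O)(C(=O)C(=O)N3CCCC[C@H]3C(=O)O[C@H](/C(C)=C/[C@@H]3CC[C@@H](Oc4cccc(O)c4)[C@H](OC)C3)[C@H](C)[C@@H](O)CC1=O)[C@H](C)C[C@@H]2OC` is the reference point here. In a functional assay on cells for inhibition, with Murine T-cell line (Mus musculus) as the target (on this read-out higher numbers stand for weaker inhibition and lower numbers for stronger inhibition), compound 1 gives 1.7 nM. Going by the values given here, the only other measured member is compound 2 `CC[C@@H]1/C=C(\C)C[C@H](C)C[C@H](OC)[C@H]2O[C@@](O)(C(=O)C(=O)N3CCCC[C@H]3C(=O)O[C@H](/C(C)=C/[C@@H]3CC[C@@H](Oc4ccc(OC)cc4)[C@H](O)C3)[C@H](C)[C@@H](O)CC1=O)[C@H](C)C[C@@H]2OC`, which in this assay gives 1.2 nM; the two numbers lie within the usual scatter of each other, so nothing separates compound 1 from compound 2 on this read-out. Compound 3 `CC[C@@H]1/C=C(\C)C[C@H](C)C[C@H](OC)[C@H]2O[C@@](O)(C(=O)C(=O)N3CCCC[C@H]3C(=O)O[C@H](/C(C)=C/[C@@H]3CC[C@@H](Oc4ccc(O)cc4)[C@H](OC)C3)[C@H](C)[C@@H](O)CC1=O)[C@H](C)C[C@@H]2OC` has not been measured. It differs from compound 1 in one place: 4-hydroxyphenyl in place of 3-hydroxyphenyl on an oxygen on a saturated carbon. The change keeps the same atoms, joined differently, and the single donor and acceptor of the ring substituent are preserved. Among the compounds with values here, with no measured step of this kind available, the step in this assay from compound 1 to compound 3 is expected to be small and in no particular direction, an estimated 1.1-fold lower number from compound 1 to compound 3 (0.03 log units; within the scatter), not beyond the scatter. Compound 3 is therefore estimated at 1.6 nM, with a range from 0.7 nM to 3.5 nM.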

Compound 3, half-maximal inhibitory concentration: 0.8 nM
For compound 3 the middle estimate is 2.0-fold (0.30 log units) above the measured one; the measured number falls inside the stated range.
By their numbers in this assay, from the lowest: compounds 3, 2 and 1 (each within the scatter of the next, the first and the last beyond it).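

Going by these compounds alone, this is the first single-place step, and it shows that the aryl group on this oxygen is not indifferent to where its hydroxyl sits. In this assay, 4-hydroxyphenyl in place of 3-hydroxyphenyl gives a 2.1-fold lower number from compound 1 to compound 3 (0.33 log units; beyond the scatter), a modest step even though the atoms and the counted donor and acceptor stay the same. Nothing at hand accounts for this step.

The compounds shown leave open what a 2-hydroxyphenyl, a plain phenyl, a 4-aminophenyl or a 4-carboxyphenyl would give on the same oxygen, and so whether the hydroxyl is needed at all. Within the data shown here, with only one such step available, it also remains open whether this change would read the same on a saturated ring carrying a hydroxyl in place of the methoxy group.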